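The compounds below may be only part of what the source reports. "The series", "measured", "known", "first", "only" and "open" are said of these compounds alone.

Measured in an ADME assay on HEK293 cells (Homo sapiens) for cytotoxicity, read by resazurin assay, with a stated time of 48 h; on this read-out higher numbers stand for lower toxicity in this test and lower numbers for higher toxicity in this test:
- compound 1 `COc1ccccc1S(=O)(=O)Nc1ccc2oc(-c3ccccc3)nc2c1`: 41000 nM
- compound 2 `O=S(=O)(Nc1ccc2oc(-c3ccccc3)nc2c1)c1cccc(O)c1`: > 100000 nM

Going by these compounds, compound 2 stands at the limit of > 100000 nM in this assay, at which 1 of the 2 values shown sits, so its exact place on the scale is unknown. Compound 3 `O=S(=O)(Nc1ccc2oc(-c3ccccc3)nc2c1)c1cccs1` has thiophen-2-yl in place of 3-hydroxyphenyl on a sulfonyl sulfur. It has not yet been measured.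

Among the measured compounds shown here, only one measured step bears on this change, since it also replaces a group on a sulfonyl sulfur: an at least 2.4-fold higher number from compound 1 to compound 2 (0.38 log units; beyond the scatter). On these data alone, that step lies beyond the scatter, and its true size is unknown because one end is a limit. Compound 3, like compound 1, lacks the 3-hydroxyphenyl group of compound 2, but a single step establishes no pattern. On the evidence of compound 1 at 41000 nM, a modest move toward lower numbers is expected. Another reading at the limit remains possible. The expected change is an at least 1.6-fold lower number from compound 2 to compound 3 (0.22 log units; that floor lies within the scatter). For compound 3 the estimated value is 60000 nM, with an expected range of 20000 nM to 150000 nM.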

Compound 3, half-maximal cytotoxic concentration: 97000 nM
The estimate for compound 3 lay 1.6-fold (0.21 log units) below the measured number; the measured number falls inside the stated range.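

In this assay the change from 2-methoxyphenyl to thiophen-2-yl on a sulfonyl sulfur gives a 2.4-fold higher number from compound 1 to compound 3 (0.37 log units; beyond the scatter), so the hydroxyl of compound 2 is not required for a number higher than that of compound 1. The 3-hydroxyphenyl and thiophen-2-yl groups differ in ring size and in hydrogen-bond donors, yet both read higher than 2-methoxyphenyl, and the step between them, an at least 1.0-fold lower number from compound 2 to compound 3 (0.01 log units; that floor lies within the scatter), does not separate them. Going by these compounds, compound 2 gives only a limit, so that comparison remains open at one end: the limit of > 100000 nM in this assay, at which 1 of the 3 values shown sits.

The compounds shown leave open whether the lower number of compound 1 belongs to the methoxy group itself or to the 2-methoxyphenyl group as a whole, and whether an unsubstituted phenyl, or a phenyl carrying an amine or a carboxylic acid, would read like compound 1 or like compound 3. On these data alone, how far the true value of compound 2 lies from that of compound 3 also remains unknown.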